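The source may report more compounds than this note shows. Statements on the series, on what has been measured and on what is new or still open speak of the compounds shown alone.

Measured so far:
Compound 1 `O=C(CCCCl)Nc1ccc(SCC(=O)Nc2ccc(Cl)cn2)cc1` — in a functional assay on A875 cells (Homo sapiens) for antiproliferative activity, read by MTT assay, with a stated time of 48 h (a higher number here means a weaker inhibitor, a lower number a stronger inhibitor), compound 1 gives > 80000 nM, a limit of the assay.
Compound 2 `CC(C)(C)C(=O)Nc1ccc(SCC(=O)Nc2ccc(Cl)cn2)cc1` — in this assay compound 2 gives > 80000 nM, again a limit of the assay.

Compound 2 thus stands at the limit, and a step that the two limits leave unreadable from compound 1 to compound 2 cannot be read from two limits. Compound 3 `O=C(CSc1ccc(NC(=O)C(Cl)(Cl)Cl)cc1)Nc1ccc(Cl)cn1` differs from compound 2 by trichloromethyl in place of tert-butyl on a carbonyl carbon. Within the data shown here, the one measured step at this carbonyl carbon is unreadable, and the limit of > 80000 nM in this assay, at which 2 of the 2 values shown sit, is all the numbers give. Compound 3 is therefore expected to remain at that limit, with a number no higher from compound 2 to compound 3 (the limit leaves the size open) expected to be nothing beyond the scatter. The estimate for compound 3 is 80000 nM, with a range from 20000 nM to 200000 nM.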

Compound 3, half-maximal inhibitory concentration: > 80000 nM
Compound 3 gave a limit, no number; the forecaster's own chance of this, stated with the estimate: 70%; the middle value lies on the limit itself.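

No step among compound 1, compound 2 and compound 3 can be read, as all three give limits rather than numbers: the limit of > 80000 nM in this assay, at which 3 of the 3 values shown sit.

The compounds shown leave open whether any group on this carbonyl carbon gives a measurable value in this assay.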